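This account rests on a few compounds, and the source may have more. Where it says the series, first, only, none or still open, it means among the compounds named here.

Three compounds built on a shared core were tested in an ADME assay on Vero cells (Chlorocebus sabaeus) for cytotoxicity; a higher number here means that more compound is tolerated, a lower number that less compound is tolerated. Compound 1 `Cc1ccc(/C=N/N(C(=O)c2ccccc2)C(=O)c2ccncc2)cc1` carries a 4-methylphenyl group on the carbon with a double bond to nitrogen, and in this assay compound 1 gives >= 20 ug/mL, which is a limit of the assay and not a number. Compound 2 `O=C(N/N=C/c1c[nH]c2ccccc12)c1ccncc1` gives > 100 ug/mL in this assay, again a limit rather than a number. Compound 3 `COc1cccc(OC)c1/C=N/NC(=O)c1ccncc1` gives 100 ug/mL in this assay. Compound 1 therefore stands only at a limit, as does compound 2; only compound 3 has a plain number, and of the three values one sits at the limit of >= 20 ug/mL in this assay, at which 1 of the 3 values shown sits, and one at the limit of > 100 ug/mL in this assay, at which 1 of the 3 values shown sits. No pair of these compounds differs in a single place, so no measured step is available.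

Compound 4 `COc1cc(/C=N/N(C(=O)c2ccccc2)C(=O)c2ccncc2)ccc1O` has not yet been tested in this assay. It differs from compound 1 in one place: 4-hydroxy-3-methoxyphenyl in place of 4-methylphenyl on a carbon with a double bond to nitrogen. Going by the values given here, with no measured step of this kind to lean on, and with all three known values sitting high, the change is expected to move the number little, within the scatter or slightly toward more compound being tolerated. Compound 4 is expected to give 50 ug/mL, with a likely range from 20 ug/mL to 100 ug/mL. The expected step that the limit leaves unreadable from compound 1 to compound 4 is taken to be nothing beyond the scatter, with a fair chance that the assay again reports only a limit.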

Compound 4, minimum cytotoxic concentration: >= 100 ug/mL
Compound 4 gave a limit, no number; the forecaster's own chance of this, stated with the estimate: 50%; middle value at least 2.0-fold (0.30 log units) from the limit.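

In this assay, compound 1 and compound 4 each give only a limit of the assay and not a number, and the step between these two compounds cannot be read. The compounds shown leave open whether 4-hydroxy-3-methoxyphenyl in place of 4-methylphenyl changes how much compound is tolerated, and if it does, by how much.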